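Amide-to-morpholine swap on the ether chain of compound 3

The source may hold more compounds than are shown below. What is called first, only, known or untested is meant among the compounds shown, and "the series" means these compounds.

Measured so far in an assay for inhibition of serine/threonine-protein kinase Sgk1 (Homo sapiens), with stated times of 30 min and 60 min, in the presence of a further agent that is not named here; on this read-out higher numbers stand for weaker inhibition and lower numbers for stronger inhibition:
compound 1 `NC(=O)c1cc(-c2ccc(NS(=O)(=O)c3cccc(Cl)c3Cl)cc2)nc2[nH]ncc12` gives 236 nM
compound 2 `CCN1CCC(CNC(=O)c2cc(-c3ccc(NS(=O)(=O)c4cccc(Cl)c4Cl)cc3)nc3[nH]ncc23)C1` gives 109 nM
compound 3 `Cc1n[nH]c2nc(-c3ccc(NS(=O)(=O)c4cc(Cl)ccc4F)cc3)nc(OCCC(=O)N(C)C)c12` gives 438 nM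

Compound 3 gives the largest of the three numbers, but its gap to compound 1 lies within the scatter, while its gap to compound 2 lies beyond it. For the measured compounds named here, the only step between measured compounds is a 2.2-fold lower number from compound 1 to compound 2 (0.34 log units; beyond the scatter), where a ring bearing a basic nitrogen is attached to an amide-type nitrogen.

Compound 4 `Cc1n[nH]c2nc(-c3ccc(NS(=O)(=O)c4cc(Cl)ccc4F)cc3)nc(OCC3CNCCO3)c12` differs from compound 3 in one place: morpholin-2-yl in place of (dimethylcarbamoyl)methyl on a saturated chain carbon bound to an oxygen on an aromatic ring. Going by the values given here, no measured pair carries this exact change. The step from compound 1 to compound 2 is the only one that bears on it, and only loosely, in that a group holding a secondary or tertiary amine enters in both cases. On that basis a modest drop in the number is expected for compound 4, of the order of a 1.8-fold lower number from compound 3 to compound 4 (0.24 log units; within the scatter), with wide uncertainty since the chain itself is also rebuilt. The estimate for compound 4 is 250 nM, expected to fall between 80 nM and 800 nM.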

Compound 4, half-maximal inhibitory concentration: 2 nM
For compound 4 the middle estimate is 130-fold (2.10 log units) above the measured one; the measured number lies below the stated range.
By their numbers in this assay, from the lowest: compound 4; then compound 2; then compounds 1 and 3 (each within the scatter of the next).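

Swapping (dimethylcarbamoyl)methyl for morpholin-2-yl on a saturated chain carbon bound to an oxygen on an aromatic ring gives a 220-fold lower number from compound 3 to compound 4 (2.34 log units; beyond the scatter) in this assay. For the compounds shown here, the heavy-atom count and the atoms themselves stay the same, so this position is highly sensitive to how those atoms are joined, which the earlier compounds could not show. No measurement shown accounts for the size of this step.

The change brings in a ring, a hydrogen-bond donor and an extra hydrogen-bond acceptor together, and the compounds shown do not separate these contributions. Going by these compounds, it remains open whether an open-chain amine such as 2-aminoethyl, a piperidine ring, or a morpholine with a methyl group on its nitrogen would keep the low number seen for compound 4.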